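Iodo to Furan-3-yl on Two Related Nucleoside Cores

This account rests on a few compounds, and the source may have more. Where it says the series, first, only, none or still open, it means among the compounds named here.

Compound 1 `Cc1ncnc2c1c(I)cn2[C@@H]1O[C@H](CO)[C@@H](O)[C@H]1O` and compound 2 `Cc1ncnc2c1c(-c1ccoc1)cn2[C@@H]1O[C@H](CO)[C@@H](O)[C@H]1O` share one core and differ by furan-3-yl in place of iodo on an aromatic carbon. In a functional assay on K562 cells (Homo sapiens), read by MTT assay, with a stated time of 72 h (a lower number here means a stronger inhibitor, a higher number a weaker inhibitor), compound 1 gives 17800 nM. Compound 2 reaches only (the limit of > 20000 nM in this assay, at which 1 of the 3 values shown sits), which is a limit of the assay rather than a number, so in this assay compound 2 gives > 20000 nM. The step of an at least 1.1-fold higher number from compound 1 to compound 2 (0.05 log units; that floor lies within the scatter) is thus bounded from one side only. Compound 3 `Cc1nc(N)c2c(I)cn([C@@H]3O[C@H](CO)[C@@H](O)[C@H]3O)c2n1` sits on another core; the difference between the two cores is not broken down here. In this assay compound 3 gives 5120 nM. Compound 4 `Cc1nc(N)c2c(-c3ccoc3)cn([C@@H]3O[C@H](CO)[C@@H](O)[C@H]3O)c2n1`, not yet measured, differs from compound 3 by furan-3-yl in place of iodo on an aromatic carbon, the same change as before. For compound 4 a step of a 2.3-fold higher number from compound 3 to compound 4 (0.37 log units; beyond the scatter) is expected, weakening in the direction set by an at least 1.1-fold higher number from compound 1 to compound 2 (0.05 log units; that floor lies within the scatter). Compound 4 is estimated at 12000 nM in this assay, between 5000 nM and 30000 nM.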

Compound 4, half-maximal inhibitory concentration: > 20000 nM
Compound 4: a limit, no number; the forecaster's own chance of this, stated with the estimate: 25%; middle value at least 1.6-fold (0.22 log units) from the limit.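

In this assay, furan-3-yl in place of iodo on the core of compound 3 gives a clear weakening, an at least 3.9-fold higher number from compound 3 to compound 4 (0.59 log units; beyond the scatter). Compound 4 gives > 20000 nM, which is a limit of the assay and not a number. The change therefore weakens inhibition beyond the scatter on this core and gives no gain on either core, but neither its true size nor any difference between the two cores can be read: the same change on two cores in this assay, an at least 1.1-fold higher number (0.05 log units; that floor lies within the scatter) from compound 1 to compound 2 and an at least 3.9-fold higher number (0.59 log units; beyond the scatter) from compound 3 to compound 4; the limit leaves it open whether they differ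

The compounds shown leave open how much weaker the two furan-3-yl compounds really are. They also leave open whether a different group on that aromatic carbon, such as an amine or a phenyl ring, would keep the activity seen with iodo.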